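A few compounds are considered here, and "the series" means these few. Any claim that something is new, unique, unknown or untested is made for them only; others in the source may bear on it.

Compound 1 `CC(=O)O[C@H]1CC[C@]2(C)[C@H](CC[C@@](C)(O)[C@H]2CC[C@@H]2C(C)=CC[C@@H]3C(C)=CC[C@@H]3C2(C)C)OC1(C)C`: 43500 nM
Compound 2 `CC1=CC[C@H]2[C@@H]1CC=C(C)[C@@H](CC[C@H]1[C@]3(C)CC[C@H](OC(=O)CCC(=O)O)C(C)(C)O[C@H]3CC[C@@]1(C)O)C2(C)C`: > 50000 nM

Both compounds were tested in a functional assay on MCF7 cells (Homo sapiens) for antiproliferative activity, read by MTT assay, with a stated time of 72 h (on this read-out higher numbers stand for weaker inhibition and lower numbers for stronger inhibition), where compound 1 gives 43500 nM. The reading for compound 2 is a limit of the assay and not a number: > 50000 nM.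

Compound 3 `CC1=CC[C@H]2[C@@H]1CC=C(C)[C@@H](CC[C@H]1[C@]3(C)CC[C@H](OC(=O)c4ccccc4)C(C)(C)O[C@H]3CC[C@@]1(C)O)C2(C)C` differs from compound 2 by phenyl in place of 2-carboxyethyl on a carbonyl carbon, with phenyl in place of 2-carboxyethyl on a carbonyl carbon. Within the data shown here, the one measured step that bears on this is an at least 1.1-fold higher number from compound 1 to compound 2 (0.06 log units; that floor lies within the scatter), where carboxymethyl took the place of hydrogen. Being a floor, it leaves the true size open. Compound 1, which lacks that carboxymethyl, gives 43500 nM, so compound 3, which also lacks it, is expected to lie near that level in this assay. The expected change is small and toward lower numbers, at an at least 1.5-fold lower number from compound 2 to compound 3 (0.18 log units; that floor lies within the scatter). The estimate for compound 3 is 33000 nM, with an expected range of 12000 nM to 70000 nM.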

Compound 3, half-maximal inhibitory concentration: 23100 nM
The estimate for compound 3 lay 1.4-fold (0.15 log units) above the measured number, and the stated range covers the measured number.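

Among these compounds, on a carbonyl carbon, phenyl in place of 2-carboxyethyl gives the first step in this assay that lies beyond the scatter, an at least 2.1-fold lower number from compound 2 to compound 3 (0.33 log units; beyond the scatter). Phenyl in place of methyl at that same place gives a 1.9-fold lower number from compound 1 to compound 3 (0.27 log units; within the scatter), so a six-membered aromatic ring is accepted there, but this step cannot be told apart from repeat-measurement noise. The first step is only a floor, and its true size stays open, since the reading for compound 2 is a limit and not a number: the limit of > 50000 nM in this assay, at which 1 of the 3 values shown sits.

As far as these compounds go, it remains open whether the step from 2-carboxyethyl to phenyl follows the loss of the carboxylic acid or the change of chain to ring, which a plain butyl chain on the same carbonyl carbon could help separate. From the compounds shown here alone, how an amine at the end of such a chain, or a fluorine on the phenyl ring, would read here also remains open.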